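Working notes: adding a phenyl to compound 2

The source may hold more compounds than are shown below. What is called first, only, known or untested is meant among the compounds shown, and "the series" means these compounds.

Measured in a functional assay on MT2 cells (Homo sapiens) for antiproliferative activity, read by MTT assay, with a stated time of 72 h; a higher number here means a weaker inhibitor of growth, a lower number a stronger inhibitor of growth:
- compound 1 `O=C(COc1ccc2oc(-c3ccccc3)cc(=O)c2c1)Nc1ccc(F)cc1`: 470 nM
- compound 2 `O=C(COc1ccc2c(=O)cc(-c3ccccc3)oc2c1)Nc1ccccc1`: > 10000 nM (a limit of the assay, not a number)

Compound 2 stands at > 10000 nM, which is a limit and gives no number to work from. the limit of > 10000 nM in this assay, at which 1 of the 2 values shown sits, is the only such entry so far. For the measured compounds named here, compound 1 at 470 nM holds the only true number.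

The next compound is compound 3 `O=C(COc1ccc2c(=O)cc(-c3ccccc3)oc2c1)Nc1ccc(-c2ccccc2)cc1`, which differs from compound 2 as follows: phenyl in place of hydrogen on an aromatic carbon. The phenyl replaces a hydrogen on an aromatic carbon, para to a large group.

Going by the values given here, no measured step gauges this change, so the size of the step is poorly constrained. Any number for compound 3 in this assay would mean stronger growth inhibition than the limit of compound 2 allows, and a modest gain is expected. Compound 3 may equally stay at the limit.

The expected change is an at least 2.0-fold lower number from compound 2 to compound 3 (0.30 log units; that floor lies within the scatter).

For compound 3 the estimated value is 5000 nM, with an expected range of 800 nM to 10000 nM.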

Compound 3, concentration for 50% growth inhibition: 2480 nM
The estimate for compound 3 lay 2.0-fold (0.30 log units) above the measured number; measured number inside the range.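

In this assay, for the compounds shown here, phenyl in place of hydrogen on an aromatic carbon, para to a large group, gives the first step that can be read at this position, an at least 4.0-fold lower number from compound 2 to compound 3 (0.60 log units; beyond the scatter), and this lies beyond the usual scatter. With compound 3 at 2480 nM, this core now has a true number, and the position accepts an added aromatic ring with stronger growth inhibition rather than a loss. Compound 2 holds a limit of the assay and not a number, so the step gives a floor and not a full size: the limit of > 10000 nM in this assay, at which 1 of the 3 values shown sits.

Still open, on these data alone, is whether the gain belongs to phenyl itself or would follow from other groups on the same aromatic carbon, such as a methoxy group, a chlorine atom or an amine. Also open, as far as these compounds go, is whether the phenyl would have a similar effect on the core of compound 1, which stands at 470 nM and differs from compound 2 in more than one place, so that the two cannot be compared directly.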